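The source may report more compounds than this note shows. Statements on the series, on what has been measured and on what is new or still open speak of the compounds shown alone.

In a functional assay on the whole organism (strain Kunming) for inhibition, with Mus musculus as the target, with a stated time of 1 h, at a dose of 40 mg/kg by the oral route (a higher number here means more inhibition at the dose given (going by the name of the read-out), a lower number less inhibition), compound 3 `O=C(/C=C/c1ccccc1)c1ccc(N2CCN(S(=O)(=O)c3ccc(Cl)cc3)CC2)cc1` gives 46.8%, the highest of the three numbers. Compound 1 `O=C(/C=C/c1ccccc1)c1ccc(N2CCN(c3ccc(Cl)c(Cl)c3)CC2)cc1` gives 13.4% and compound 2 `O=C(/C=C/c1ccccc1)c1ccc(N2CCN(c3ccccc3F)CC2)cc1` gives 0.57%. Both measured steps into compound 3 were large, a number 33.4 percentage points higher from compound 1 to compound 3 (beyond the scatter) and a number 46.2 percentage points higher from compound 2 to compound 3 (beyond the scatter), and each put a sulfonyl group on the amine nitrogen in the ring in place of an aryl group. Compound 4 `Cc1cc(C)c(S(=O)(=O)N2CCN(c3ccc(C(=O)/C=C/c4ccccc4)cc3)CC2)c(C)c1` keeps that sulfonyl and differs from compound 3 only there: 2,4,6-trimethylphenyl in place of 4-chlorophenyl on a sulfonyl sulfur. Within the data shown here, no measured step alters the group on the sulfonyl sulfur, so the three numbers speak to neither the size nor the direction of this change. Compound 4 is therefore expected to stay near compound 3, with a number 4.8 percentage points lower from compound 3 to compound 4 (within the scatter) judged not beyond the scatter. The estimate for compound 4 is 42%, in the range 20% to 62%.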

Compound 4, a percentage reported as inhibition, in the whole organism at one dose (the size of the read-out at that dose, not a potency): 55.5%
For compound 4 the middle estimate is 13.5 percentage points below the measured one; the range from low to high includes it.
By their numbers in this assay, from the lowest: compound 2; then compound 1; then compounds 3 and 4 (each within the scatter of the next).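

In this assay, the group on the sulfonyl sulfur could be exchanged without a shift beyond the scatter: a number 8.7 percentage points higher from compound 3 to compound 4 (within the scatter). Within this pair, the chlorine atom is therefore not required to keep the read-out at this level, and 2,4,6-trimethylphenyl serves as well as 4-chlorophenyl. Nothing measured on these compounds offers an explanation for this. On these data alone, whether that sulfur needs an aromatic ring at all remains open, and a simple methyl or a longer alkyl chain there would address this.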